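Bromo for methoxy on the pyridine of the cyclopropane-fused core

The source may hold more compounds than are shown below. What is called first, only, known or untested is meant among the compounds shown, and "the series" means these compounds.

Measured so far, all in an assay on CHO-K1 cells for displacement of a labelled ligand from Neuronal acetylcholine receptor; alpha4/beta2 (Homo sapiens), read by scintillation counting; a higher number here means a weaker inhibitor, a lower number a stronger inhibitor:
compound 1 `FC(F)(F)c1ccc(OC[C@@H]2C[C@H]3C[C@H]3N2)cn1`, 768 nM
compound 2 `COc1ccc(OC[C@@H]2C[C@H]3C[C@H]3N2)cn1`, > 10000 nM
compound 3 `COc1ccc(OC[C@@H]2C[C@@H]3C[C@@H]3N2)cn1`, 4.7 nM

Compound 2 stands at the weak end of the numbers shown. Its value in this assay is a limit of the assay and not a number (the limit of > 10000 nM in this assay, at which 1 of the 3 values shown sits). Compound 3 shares all atoms and bonds with compound 2 and differs only in configuration as drawn (the fact that compounds 2 and 3 differ only in the configuration as drawn); the step of an at least 2100-fold lower number from compound 2 to compound 3 (3.32 log units; beyond the scatter) is large. Compound 1 carries the same configuration as compound 2, and the step of an at least 13-fold higher number from compound 1 to compound 2 (1.11 log units; beyond the scatter) shows that swapping trifluoromethyl for methoxy on the aromatic carbon moved the number up by a large amount.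

Compound 4 `Brc1ccc(OC[C@@H]2C[C@H]3C[C@H]3N2)cn1` is not yet measured. It keeps the configuration of compound 2 and changes only the aromatic substituent: bromo in place of methoxy on an aromatic carbon.

The step that bears on this change is an at least 13-fold higher number from compound 1 to compound 2 (1.11 log units; beyond the scatter), since it also removes or installs methoxy at the same aromatic carbon while the rest of the molecule, configuration included, is unchanged. Read in reverse, it suggests that leaving methoxy for a small non-acceptor substituent should bring the number down, in the direction of compound 1. The step of an at least 2100-fold lower number from compound 2 to compound 3 (3.32 log units; beyond the scatter) does not bear directly on it. Compound 4 keeps the configuration of compound 2 rather than that of compound 3.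

For compound 4 a lower number than the limit of compound 2 is therefore expected, in this assay, with the expected step being an at least 6.6-fold lower number from compound 2 to compound 4 (0.82 log units; beyond the scatter). The estimate for compound 4 is 1500 nM, with a range from 300 nM to 8000 nM.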

Compound 4, inhibition constant: 46.5 nM
Compound 4: middle estimate off by 32-fold (1.51 log units), on the high side; the measured number lies below the stated range.
By their numbers in this assay, from the lowest: compound 3; then compound 4; then compound 1. At a limit, above all of these: compound 2.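

Compound 2 gives > 10000 nM in this assay, which is a limit of the assay and not a number. With the configuration held, the substituent on the aromatic carbon next to the ring nitrogen has a far larger reach than the earlier methoxy and trifluoromethyl pair showed: bromo in place of methoxy gives an at least 210-fold lower number from compound 2 to compound 4 (2.33 log units; beyond the scatter), and bromo in place of trifluoromethyl gives a 17-fold lower number from compound 1 to compound 4 (1.22 log units; beyond the scatter). The configuration of compound 2 therefore does not by itself hold the number at the weak end, and of the three substituents shown on that configuration, bromo gives the lowest number.

Methoxy is the only substituent shown on both configurations, so whether bromo on the configuration of compound 3 would move the number in the same direction remains open. Also open, going by these compounds, is where a chloro, a nitrile or an amine on the same aromatic carbon would fall relative to bromo, methoxy and trifluoromethyl, since three substituents give an order and no trend.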